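Sulfanyl for alkoxy-amine at the core of compound 2

The compounds below may be only part of what the source reports. "The series", "measured", "known", "first", "only" and "open" are said of these compounds alone.

Three compounds share the core and are measured in an assay on IMR-32 cells for displacement of a labelled ligand from corticotropin-releasing factor receptor 1 (Homo sapiens), read by scintillation counting, with a stated time of 2 h; on this read-out lower numbers stand for stronger inhibition and higher numbers for weaker inhibition. Compound 1 `CCc1nc(NC(CC)CC)c(Cl)nc1-c1ccc(Cl)cc1Cl` gives 71 nM. Among the compounds with values here, compound 3 `CCc1nc(NC(CC)CC)c(OC)nc1-c1ccc(Cl)cc1Cl` gives 5.9 nM; the single step of a 12-fold lower number from compound 1 to compound 3 (1.08 log units; beyond the scatter) is the only one-place change measured so far. Compound 2 `CCc1nc(-c2ccc(Cl)cc2Cl)c(CC)nc1NC(COC)COC` gives 224 nM and stands highest of the three numbers, beyond the scatter from both compound 1 and compound 3.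

Compound 4 `CCc1nc(-c2ccc(Cl)cc2Cl)c(CC)nc1SC(C)CC` is not yet measured. Its change from compound 2 is (sec-butyl)sulfanyl in place of (2-methoxy-1-(methoxymethyl)ethyl)amino on an aromatic carbon. Within the data shown here, no measured step touches this position in this way, so the size of the step cannot be read from a measured pair. Compound 1 and compound 3, which carry a branched alkylamino group at that carbon, show lower numbers than compound 2, and compound 4 moves to a branched alkyl group as well, though on sulfur. Compound 4 is therefore expected to give a somewhat lower number than compound 2, as a modest step of a 2.5-fold lower number from compound 2 to compound 4 (0.40 log units; beyond the scatter). For compound 4 the estimate in this assay is 90 nM, with a range from 25 nM to 350 nM.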

Compound 4, inhibition constant: 401 nM
Compound 4: middle estimate off by 4.5-fold (0.65 log units), on the low side, and the stated range ends below it.
By their numbers in this assay, from the lowest: compound 3; then compound 1; then compounds 2 and 4 (each within the scatter of the next).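

In this assay, (sec-butyl)sulfanyl in place of (2-methoxy-1-(methoxymethyl)ethyl)amino on this aromatic carbon gives a 1.8-fold higher number from compound 2 to compound 4 (0.25 log units; within the scatter), so the two compounds cannot be told apart on this read-out. Within the data shown here, this is the only measured step at this position, and the number stays within the usual scatter although the entering group has 0 hydrogen-bond donors and 5 heavy atoms, against 1 and 8 for the leaving group. No measurement among the data bears on why this exchange leaves the number within the scatter.

From the compounds shown here alone, the step changes the linking atom and the chain together, so the part played by each remains open. A (sec-butyl)amino group at this carbon, on the core of compound 2, would separate the two changes.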